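A few compounds are considered here, and "the series" means these few. Any claim that something is new, unique, unknown or untested is made for them only; others in the source may bear on it.

Measured in a functional assay on BXPC-3 cells (Homo sapiens) for antiproliferative activity, read by MTT assay, with a stated time of 24 h; on this read-out higher numbers stand for weaker inhibition and lower numbers for stronger inhibition:
- compound 1 `CCn1c(C(=O)N[C@@H](C)C(=O)OC)ccc1C(CC)(CC)c1ccc(OCS(=O)(=O)c2ccccc2)c(C)c1`: 17900 nM
- compound 2 `CCn1c(C(=O)NCCN)ccc1C(CC)(CC)c1ccc(OCS(=O)(=O)c2ccccc2)c(C)c1`: 6430 nM
- compound 3 `CCn1c(C(=O)NCCO)ccc1C(CC)(CC)c1ccc(OCS(=O)(=O)c2ccccc2)c(C)c1`: 19900 nM

Compound 3 sits at the upper end of these numbers, level with compound 1 and clear of compound 2.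

Compound 4 `CCn1c(C(=O)N[C@H](CO)C(C)C)ccc1C(CC)(CC)c1ccc(OCS(=O)(=O)c2ccccc2)c(C)c1` differs from compound 3 by isopropyl in place of hydrogen on a saturated chain carbon bound to an amide-type nitrogen and a saturated chain carbon.

Among the measured compounds shown here, no measured step tests isopropyl at this carbon. The closest evidence is a 1.1-fold higher number from compound 1 to compound 3 (0.05 log units; within the scatter), a change of the group on the amide-type nitrogen. The other relevant step is a 3.1-fold higher number from compound 2 to compound 3 (0.49 log units; beyond the scatter), hydroxy in place of amino, and compound 4 keeps the hydroxy. No step beyond the scatter is therefore expected in this assay. The expected step is a 1.2-fold lower number from compound 3 to compound 4 (0.09 log units; within the scatter). For compound 4 the estimated value is 16000 nM, with an expected range of 7500 nM to 34000 nM.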

Compound 4, half-maximal inhibitory concentration: 7720 nM
Beside the measured number, compound 4's estimate is 2.1-fold (0.32 log units) above it; the measured number falls inside the stated range.
By their numbers in this assay, from the lowest: compounds 2 and 4 (each within the scatter of the next); then compounds 1 and 3 (each within the scatter of the next).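

In this assay, substitution at the saturated chain carbon bound to an amide-type nitrogen moves the number: isopropyl in place of hydrogen, with the hydroxy kept, gives a 2.6-fold lower number from compound 3 to compound 4 (0.41 log units; beyond the scatter). The 1-(hydroxymethyl)-2-methylpropyl group therefore reaches the level of 2-aminoethyl without an amino group (a 1.2-fold higher number from compound 2 to compound 4 (0.08 log units; within the scatter)) and stands clear of 1-(methoxycarbonyl)ethyl (a 2.3-fold lower number from compound 1 to compound 4 (0.37 log units; beyond the scatter)). No measurement at hand accounts for this step.

Open, as far as these compounds go, are a methyl or a phenyl at this carbon. Also open, from the compounds shown here alone, is an amine in place of the hydroxy of compound 4, which would show whether the isopropyl and amino steps add.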